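Thioether series: fluorophenyl to methoxyphenyl swap

This account rests on a few compounds, and the source may have more. Where it says the series, first, only, none or still open, it means among the compounds named here.

Measured so far:
- compound 1 `C#CCNC1CCc2c(SCCc3ccc(Br)cc3)cccc21`: 85300 nM
- compound 2 `C#CCNC1CCc2c(SCCc3ccc(Cl)cc3)cccc21`: 10800 nM
- compound 3 `C#CCNC1CCc2c(SCCc3cccc(F)c3)cccc21`: 4300 nM

In an assay on isolated protein for inhibition of Amine oxidase [flavin-containing] B (Homo sapiens) (on this read-out lower numbers stand for stronger inhibition and higher numbers for weaker inhibition), compound 3 stands lowest of the three numbers; compound 2 is nearest, and compound 1 furthest. The two steps leading to compound 3 were a 2.5-fold lower number from compound 2 to compound 3 (0.40 log units; beyond the scatter) and a 20-fold lower number from compound 1 to compound 3 (1.30 log units; beyond the scatter), while a 7.9-fold lower number from compound 1 to compound 2 (0.90 log units; beyond the scatter) separates the two halogen compounds.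

Compound 4 `C#CCNC1CCc2c(SCCc3ccc(OC)cc3)cccc21` is not yet measured. The change from compound 3 is 4-methoxyphenyl in place of 3-fluorophenyl on a saturated chain carbon, two bonds along the chain from a sulfur. Among the measured compounds shown here, no measured step involves a methoxy group, so the expectation rests on the pattern that the 4-chlorophenyl of compound 2 and the 4-bromophenyl of compound 1 both gave higher numbers than the 3-fluorophenyl of compound 3; the 4-methoxyphenyl of compound 4 resembles those two in the name of its substituent position rather than the 3-fluorophenyl. The expected step in this assay is therefore modest and upward, with wide uncertainty because a 7.9-fold lower number from compound 1 to compound 2 (0.90 log units; beyond the scatter) shows the substituent itself matters strongly. Compound 4 is estimated at 9000 nM, with a range from 3000 nM to 30000 nM; this corresponds to an expected step of a 2.1-fold higher number from compound 3 to compound 4 (0.32 log units; beyond the scatter).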

Compound 4, half-maximal inhibitory concentration: 62000 nM
Estimate against measurement, compound 4: 6.9-fold (0.84 log units) below; the measured number lies above the stated range.
By their numbers in this assay, from the lowest: compound 3; then compound 2; then compounds 4 and 1 (each within the scatter of the next).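

In this assay, 4-methoxyphenyl in place of 3-fluorophenyl on a saturated chain carbon, two bonds along the chain from a sulfur, gives a 14-fold higher number from compound 3 to compound 4 (1.16 log units; beyond the scatter), which leaves compound 3 as the strongest inhibitor of the four. Among the three para-free-named 4-substituted phenyl compounds, methoxy in place of chloro gives a 5.7-fold higher number from compound 2 to compound 4 (0.76 log units; beyond the scatter), whereas methoxy in place of bromo gives a 1.4-fold lower number from compound 1 to compound 4 (0.14 log units; within the scatter), so compound 2 stands apart from both while compound 1 and compound 4 cannot be told apart. The data shown offer no measured explanation for this ordering.

The compounds shown leave open whether the low number of compound 3 belongs to the fluoro group itself or to the 3-substituted ring, as a change of group and of its place are joined in every step to compound 3. A 4-fluorophenyl and a 3-methoxyphenyl would separate these two readings, and an unsubstituted phenyl would give the reference against which each substituent could be judged.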